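The source may report more compounds than this note shows. Statements on the series, on what has been measured and on what is new or still open speak of the compounds shown alone.

Compound 1 `COc1ccc(C(=O)/C=C/c2ccc(C(=O)Nc3cc([N+](=O)[O-])ccc3O)cc2)c(O)c1`: in an ADME assay on SH-SY5Y cells (Homo sapiens) for cytotoxicity, read by MTT assay, with a stated time of 48 h (on this read-out lower numbers stand for stronger inhibition and higher numbers for weaker inhibition), compound 1 gives > 100000 nM, which is a limit of the assay rather than a number.
Compound 2 `COc1ccc(C(=O)/C=C/c2ccc(C(=O)O)cc2)c(O)c1`: in this assay compound 2 gives > 100000 nM, again a limit.
Compound 3 `COc1ccc(C(=O)/C=C/c2ccc(OCc3ccccc3)cc2)c(O)c1`: in this assay compound 3 gives > 100000 nM, also a limit.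

Compound 2 therefore stands at the limit, and so does every other compound measured here. Within the data shown here, the one step among them, a step that the two limits leave unreadable from compound 2 to compound 3, cannot be read, since both ends are limits.

Compound 4 `COc1ccc(C(=O)/C=C/c2ccc(C(=O)Nc3ccccc3OC)cc2)c(O)c1` is not yet measured. It arises from compound 2 by the change ((2-methoxyphenyl)amino in place of hydroxy on a carbonyl carbon). Compound 1 also carries a nitrogen-linked aromatic group on that carbonyl carbon, and it too sits at the limit, as all three do: the limit of > 100000 nM in this assay, at which 3 of the 3 values shown sit. Among the measured compounds shown here, no measured step gives a readable size, in either direction, for any change on this core, and nothing separates the amide of compound 1 from the acid of compound 2 or the ether of compound 3.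

The expectation for compound 4 is thus a step of a number no higher from compound 2 to compound 4 (the limit leaves the size open), meaning no movement beyond the scatter and most probably another limit. Compound 4 is estimated at 100000 nM, within 50000 nM to 300000 nM.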

Compound 4, half-maximal inhibitory concentration: > 100000 nM
Compound 4 ended at the assay's limit; the forecaster's own chance of this, stated with the estimate: 85%; the middle value sits exactly at the limit.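

In this assay compound 4 gives > 100000 nM, which is a limit and not a number. The comparisons of compound 4 with compound 2 and with compound 1 cannot be read, as each has a limit at both ends. All four compounds sit together: the limit of > 100000 nM in this assay, at which 4 of the 4 values shown sit.

The compounds shown leave open which change on the shared core, if any, would give a readable number.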